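Swapping phenyl for 4-ethylpyridin-2-yl at the toxicity limit

The source may hold more compounds than are shown below. What is called first, only, known or untested is meant among the compounds shown, and "the series" means these compounds.

Two related compounds have been tested so far in an ADME assay on HEK293 cells (Homo sapiens) for cytotoxicity, read by resazurin assay, with a stated time of 72 h; on this read-out higher numbers stand for lower toxicity in this test and lower numbers for higher toxicity in this test: compound 1 `CCc1cccc(CNC(=O)c2nc3c(COCc4ccc(C(=O)O)cc4)cccc3c(=O)[nH]2)c1` and compound 2 `O=C(O)c1ccc(COCc2cccc3nc(C(=O)NCc4ccccc4)[nH]c(=O)c23)cc1`. Compound 1 gives > 20000 nM, which is a limit of the test and not a number. Compound 2 gives > 20000 nM, which is also a limit and not a number. Compound 2 therefore stands at the end of the measurable range, and the summary is short: the limit of > 20000 nM in this assay, at which 2 of the 2 values shown sit. Neither result gives an exact figure, so the two compounds cannot be ranked.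

Compound 3 `CCc1ccnc(CNC(=O)c2nc3cccc(COCc4ccc(C(=O)O)cc4)c3c(=O)[nH]2)c1` differs from compound 2 in one place: 4-ethylpyridin-2-yl in place of phenyl on a saturated chain carbon bound to an amide-type nitrogen. Here, 4-ethylpyridin-2-yl takes the place of phenyl on a saturated chain carbon bound to an amide-type nitrogen. Among the measured compounds shown here, no tested pair shows this change on its own, so the expectation rests on both tested compounds reaching the limit. No shift in either direction beyond the usual scatter is expected in this assay, and another result at the limit is the likeliest outcome. The estimated step that the limit leaves unreadable from compound 2 to compound 3 is accordingly small. For compound 3 the expected value is 22000 nM, with an estimated range from 10000 nM to 45000 nM.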

Compound 3, half-maximal cytotoxic concentration: > 20000 nM
Compound 3: a limit, no number; the forecaster's own chance of this, stated with the estimate: 85%; the middle value does not contradict the limit.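

In this assay compound 3 gives > 20000 nM, which is a limit of the test and not a number. Among the compounds shown here, compound 2 also sits at a limit, so no step between compound 2 and compound 3 can be read. The compounds shown leave open whether they differ in toxicity at all, and at what concentration each would harm these cells, with the picture so far being this: the limit of > 20000 nM in this assay, at which 3 of the 3 values shown sit.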